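This account rests on a few compounds, and the source may have more. Where it says the series, first, only, none or still open, it means among the compounds named here.

Measured in a functional assay on A549 cells (Homo sapiens) for antiproliferative activity, read by MTT assay, with a stated time of 72 h; a lower number here means a stronger inhibitor, a higher number a weaker inhibitor:
- compound 1 `COc1cc(F)c(NC(=O)c2ccnc(Cl)c2)cc1Nc1nccc(-c2cn(C)c3ccccc23)n1`: 6890 nM
- compound 2 `COc1cc(F)c(NC(=O)c2ccncc2OC)cc1Nc1nccc(-c2cn(C)c3ccccc23)n1`: 3430 nM
- compound 3 `COc1cc(N(C)CCN(C)C)c(NC(=O)c2ccnc(Cl)c2)cc1Nc1nccc(-c2cn(C)c3ccccc23)n1`: 970 nM

Compound 3 gives the lowest number of the three in this assay; compound 2 is nearest to it and compound 1 furthest, both gaps beyond the scatter. Compound 4 `COc1cc(N(C)CCN(C)C)c(NC(=O)c2ccncc2OC)cc1Nc1nccc(-c2cn(C)c3ccccc23)n1` differs from compound 3 by 3-methoxypyridin-4-yl in place of 2-chloropyridin-4-yl on a carbonyl carbon. Within the data shown here, one measured step bears directly on this change: a 2.0-fold lower number from compound 1 to compound 2 (0.30 log units; within the scatter), which is within the scatter. The other step, a 7.1-fold lower number from compound 1 to compound 3 (0.85 log units; beyond the scatter), concerns the part that compound 3 and compound 4 share and so gives no guidance here. With a single small precedent, no step beyond the scatter is expected; the estimated step is a 1.9-fold lower number from compound 3 to compound 4 (0.29 log units; within the scatter). Compound 4 is therefore expected at about 500 nM, with a range from 200 nM to 1500 nM.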

Compound 4, half-maximal inhibitory concentration: 2690 nM
The estimate for compound 4 lay 5.4-fold (0.73 log units) below the measured number; measured number above the stated range.
By their numbers in this assay, from the lowest: compound 3; then compounds 4, 2 and 1 (each within the scatter of the next, the first and the last beyond it).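

With the (2-(dimethylamino)ethyl)(methyl)amino group present, 3-methoxypyridin-4-yl on the carbonyl carbon gives a 2.8-fold higher number from compound 3 to compound 4 (0.44 log units; beyond the scatter) in this assay so this change does not read the same on the two cores: the same change on two cores in this assay, a 2.0-fold lower number (0.30 log units; within the scatter) from compound 1 to compound 2 and a 2.8-fold higher number (0.44 log units; beyond the scatter) from compound 3 to compound 4, 5.6-fold (0.75 log units) apart, beyond the scatter of two such steps.

With 3-methoxypyridin-4-yl in place, the swap of fluoro for that amino group gives only a 1.3-fold lower number from compound 2 to compound 4 (0.11 log units; within the scatter) so the two changes do not add up across these four compounds: the same change on two cores in this assay, a 7.1-fold lower number (0.85 log units; beyond the scatter) from compound 1 to compound 3 and a 1.3-fold lower number (0.11 log units; within the scatter) from compound 2 to compound 4, 5.6-fold (0.75 log units) apart, beyond the scatter of two such steps.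

Open, as far as these compounds go, is whether this dependence extends to other groups, such as a morpholine on the aromatic carbon or an unsubstituted pyridine on the carbonyl carbon.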